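Swapping vinyl for methylsulfanyl on a shared core

The source may report more compounds than this note shows. Statements on the series, on what has been measured and on what is new or still open speak of the compounds shown alone.

Measured so far:
compound 1 `Nc1nc2ccc(OCC(F)(F)C(F)(F)F)cc2s1` gives 7.5 mg/kg
compound 2 `C=CCn1c(=N)sc2cc(OC(F)(F)F)ccc21` gives 7 mg/kg

Both were tested in a functional assay on the whole organism with Rattus norvegicus as the target; a lower number here means that less compound is needed, a higher number that more compound is needed for the effect. Compound 2 has the lowest of the two numbers, yet compound 1 sits within the scatter of it, so the two cannot be ranked. Compound 3 `CSCn1c(=N)sc2cc(OC(F)(F)F)ccc21` differs from compound 2 in one place: methylsulfanyl in place of vinyl on a saturated chain carbon bound to an aromatic nitrogen. Among the measured compounds shown here, no measured pair shows what such a change does here, so a step of a 1.1-fold higher number from compound 2 to compound 3 (0.06 log units; within the scatter) is expected, without a clear direction and not beyond the scatter. Compound 3 is thus estimated at 8 mg/kg, between 3 mg/kg and 20 mg/kg.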

Compound 3, dose for half-maximal effect: 3 mg/kg
Compound 3: the middle estimate sits 2.7-fold (0.43 log units) above what was measured, and the stated range covers the measured number.
By their numbers in this assay, from the lowest: compound 3; then compounds 2 and 1 (each within the scatter of the next).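

In this assay, replacing vinyl with methylsulfanyl on a saturated chain carbon bound to an aromatic nitrogen gives a 2.3-fold lower number from compound 2 to compound 3 (0.37 log units; beyond the scatter) and so shows that the number responds to what this chain carries. Among the compounds shown here, this is the first step here between compounds that differ in one place, and it is modest. Nothing available explains it. One swap cannot tell whether the sulfur or the loss of the double bond matters. Going by these compounds, how a longer chain, an amine or a methoxy group would fare at this place also stays open.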